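A few compounds are considered here, and "the series" means these few. Any claim that something is new, unique, unknown or untested is made for them only; others in the source may bear on it.

Compound 1 `O=C(C1CCCC1)N1CCc2nc(C#Cc3ccccc3)sc2C1` and compound 2 `O=C(CC1CCOCC1)N1CCc2nc(C#Cc3ccccc3)sc2C1` share one core and differ only in the group on the carbonyl carbon. Among the compounds with values here, in an assay on HEK293 cells for positive allosteric modulation of metabotropic glutamate receptor 5 (Homo sapiens), read by FLIPR, with a stated time of 1 h (a higher number here means that more compound is needed for the effect, a lower number that less compound is needed), compound 1 gives 19 nM and compound 2 gives 470 nM; the change between them is a 25-fold higher number from compound 1 to compound 2 (1.39 log units; beyond the scatter), so compound 2 stands as the higher of the two numbers measured so far. Compound 3 `O=C(N1CCCCC1)N1CCc2nc(C#Cc3ccccc3)sc2C1` is not yet measured and differs from compound 2 by piperidin-1-yl in place of (oxan-4-yl)methyl on a carbonyl carbon. Within the data shown here, the single measured step that bears on this carbonyl carbon is a 25-fold higher number from compound 1 to compound 2 (1.39 log units; beyond the scatter), a large move when cyclopentyl gave way to (oxan-4-yl)methyl. Compound 3 again has a ring attached directly to the carbonyl carbon, as compound 1 does, where compound 2 carries (oxan-4-yl)methyl. A downward step in this assay is therefore expected; the expected step is a 7.8-fold lower number from compound 2 to compound 3 (0.89 log units; beyond the scatter), without reaching the certainty of a return to compound 1. Compound 3 is estimated at 60 nM, with a range from 15 nM to 250 nM.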

Compound 3, half-maximal effective concentration: 75 nM
Beside the measured number, compound 3's estimate is 1.3-fold (0.10 log units) below it; the measured number falls inside the stated range.
By their numbers in this assay, from the lowest: compound 1; then compound 3; then compound 2.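

In this assay, a 6.3-fold lower number from compound 2 to compound 3 (0.80 log units; beyond the scatter) shows that much of the large rise seen with (oxan-4-yl)methyl is absent when a different ring, piperidin-1-yl, sits directly on the carbonyl carbon, so cyclopentyl is not the only directly attached ring that gives a low number here. Even so, a 3.9-fold higher number from compound 1 to compound 3 (0.60 log units; beyond the scatter) and this gap lies beyond the scatter, so the two directly attached rings are not interchangeable at this position. Nothing at hand accounts for either step.

The step from compound 2 to compound 3 changes the ring hetero atom and the mode of attachment together, so the compounds shown cannot separate these two changes. Cyclopentylmethyl or oxan-4-yl on the same carbonyl carbon would bear on that question.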